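This account rests on a few compounds, and the source may have more. Where it says the series, first, only, none or still open, it means among the compounds named here.

Measured so far:
compound 1, `COc1ccc(CNc2nc([Se]C)nc3ccccc23)cc1`: > 100000 nM in a functional assay on CCRF-CEM cells (Homo sapiens) for cytotoxicity, read by MTT assay, with a stated time of 72 h; a lower number here means a stronger inhibitor of growth, a higher number a weaker inhibitor of growth; this is a limit of the assay, not a number.
compound 2, `CCCCC[Se]c1nc([Se]CCCCC)c2cccnc2n1`: > 100000 nM in this assay; likewise a limit.

Compound 1 thus stands at the limit of this assay, with no number known for it, and compound 2 sits at the same limit (the limit of > 100000 nM in this assay, at which 2 of the 2 values shown sit). Compound 3, `COc1ccc(CNc2nc([SeH])nc3ccccc23)cc1`, is not yet measured; it differs from compound 1 by hydrogen in place of methyl on a selenium. With both shown values at the limit, no step beyond the scatter is expected, and compound 3 is expected to remain at that limit. The expected step of a number no higher from compound 1 to compound 3 (the limit leaves the size open) is none beyond the scatter. Compound 3 is estimated at 100000 nM, range 30000 nM to 300000 nM.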

Compound 3, concentration for total growth inhibition: > 100000 nM
Compound 3 gave a limit, no number (the forecaster's own chance of this, stated with the estimate: 80%); the middle value lies on the limit itself.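

No step can be read between compound 1 and compound 3, with hydrogen in place of methyl on a selenium, as both values are limits: the limit of > 100000 nM in this assay, at which 3 of the 3 values shown sit.

The compounds shown leave open which structural change, if any, would bring a measurable value in this assay.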